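The compounds below may be only part of what the source reports. "The series", "measured", "known", "first", "only" and "open" are said of these compounds alone.

Compound 1 `COc1cccc(OC)c1N1C(=O)CSC1c1cccc(C(=O)NCCCCc2ccccc2)c1`: 80%
Compound 2 `O=C(NCCCCc1ccccc1)c1cccc(C2OCC(=O)N2c2cccc(F)c2)c1`: 66%
Compound 3 `COc1ccccc1N1C(=O)CSC1C(=O)NCCCCc1ccccc1`: 60%

These three compounds were tested in a functional assay on MG-63 cells (Homo sapiens) for inhibition, read by CCK-8 assay, with a stated time of 72 h, tested at 1 uM; a higher number here means more inhibition at the concentration tested (going by the name of the read-out), a lower number less inhibition. Compound 1 stands highest of the three numbers; compound 2 is nearest, lower by more than the usual scatter, and compound 3 is furthest, also lower beyond the scatter. For the measured compounds named here, no two of the measured compounds differ in one place only, so no measured step is available for comparison.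

Compound 4 `COc1ccc(F)cc1N1C(=O)CSC1c1cccc(C(=O)NCCCCc2ccccc2)c1` is the next compound to be measured. Relative to compound 1 it carries 5-fluoro-2-methoxyphenyl in place of 2,6-dimethoxyphenyl on an amide-type nitrogen in a ring. Going by the values given here, since no measured step informs this change, the expected step from compound 1 to compound 4 in this assay is small, either none beyond the scatter or a slight fall, estimated as a number 8 percentage points lower from compound 1 to compound 4 (within the scatter). Compound 4 is therefore expected to give about 72%, with a range from 55% to 88%.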

Compound 4, a percentage reported as inhibition, at one concentration (the size of the read-out at that concentration, not a potency): 86%
Compound 4: the middle estimate sits 14 percentage points below what was measured; low and high end bracket the measured number.
By their numbers in this assay, from the lowest: compounds 3 and 2 (each within the scatter of the next); then compounds 1 and 4 (each within the scatter of the next).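

In this assay, the first step measured at this position is a number 6 percentage points higher from compound 1 to compound 4 (within the scatter), so 5-fluoro-2-methoxyphenyl in place of 2,6-dimethoxyphenyl on the amide-type nitrogen leaves the read-out unresolved from that of the parent. Inhibition at the concentration tested therefore does not depend on keeping the 2,6-dimethoxyphenyl group intact at this place. Nothing measured here offers a reason for this outcome.

The compounds shown leave open whether the fluorine or the single methoxy group carries the result. They also leave open how an unsubstituted phenyl or a pyridine ring would fare at this position.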